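Cyclohexyl to 4-methylphenyl on the piperazine nitrogen of compound 1

The compounds below may be only part of what the source reports. "The series", "measured", "known", "first", "only" and "open" are said of these compounds alone.

Of the compounds shown here, three that share one core have been measured in a functional assay on MGC-803 cells (Homo sapiens) for antiproliferative activity, read by CCK-8 assay, with a stated time of 72 h, tested at 2 uM; on this read-out lower numbers stand for a weaker effect and higher numbers for a stronger effect at the one concentration tested. Compound 1 `Nc1ccccc1NC(=O)c1ccc(CSC(=S)N2CCN(C3CCCCC3)CC2)cc1` gives 16.9% in this assay and stands lowest of the three. Compound 2 `Nc1ccccc1NC(=O)c1ccc(CSC(=S)N2CCc3ccc([N+](=O)[O-])cc32)cc1` gives 30.6%, and compound 3 `Nc1ccccc1NC(=O)c1ccc(CSC(=S)N2CCc3ccccc32)cc1` gives 44%, both beyond the scatter above compound 1. Within the data shown here, the one step that can be computed within this set, a number 13.4 percentage points higher from compound 2 to compound 3 (beyond the scatter), is a modest one and concerns a nitro group that compound 1 and compound 4 do not carry.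

Compound 4 `Cc1ccc(N2CCN(C(=S)SCc3ccc(C(=O)Nc4ccccc4N)cc3)CC2)cc1` differs from compound 1 in one place: 4-methylphenyl in place of cyclohexyl on an amine nitrogen in a ring. Among the measured compounds shown here, no measured pair tests this exchange directly, so no step in the data bears on it. What the numbers do show is that compound 2 and compound 3, which carry an aromatic ring on the ring nitrogen where compound 1 carries cyclohexyl, both sit higher than compound 1 in this assay. On that basis compound 4 is expected to move upward from compound 1 by a number 13.1 percentage points higher from compound 1 to compound 4 (beyond the scatter), a step that need not clear the scatter. The estimate for compound 4 in this assay is 30%, with a range from 12% to 50%.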

Compound 4, a percentage reported as inhibition, at one concentration (the size of the read-out at that concentration, not a potency): 33.4%
The estimate for compound 4 lay 3.4 percentage points below the measured number, and the stated range covers the measured number.
By their numbers in this assay, from the lowest: compound 1; then compounds 2 and 4 (each within the scatter of the next); then compound 3.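

In this assay, among these compounds, the exchange on the amine nitrogen of the six-membered non-aromatic ring with 2 nitrogen gives a number 16.5 percentage points higher from compound 1 to compound 4 (beyond the scatter), the first direct reading of this position in the set. The earlier compounds shown here could only hint at this, as compound 2 and compound 3 differ from compound 1 in more than one place, whereas here the rest of the molecule stays fixed and only cyclohexyl gives way to 4-methylphenyl. The step therefore shows that this nitrogen tolerates an aromatic ring of carbon only in place of a non-aromatic one without loss of inhibition at the one concentration tested, though no measurement at hand gives a reason for the step.

The change replaces the non-aromatic ring with an aromatic one and adds a methyl group in a single move, so the two contributions cannot be told apart from these compounds. A plain phenyl on this nitrogen would separate them, and a benzyl or a 4-aminophenyl would show how far the gain extends to other groups at this position.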